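Chloro substitution on an aminophenyl pyrazoline amide

The compounds below may be only part of what the source reports. "The series", "measured", "known", "first", "only" and "open" are said of these compounds alone.

Compound 1 `Nc1ccc(Cl)cc1C1=NN(C(=O)c2ccccc2)CC1`: 17%
Compound 2 `CC(=O)N1CCC(c2ccccc2N)=N1`: 7.73%
Compound 3 `Nc1ccccc1C1=NN(C(=O)c2ccccc2)CC1`: 8.7%

These three compounds were measured in an assay on isolated protein for inhibition of Nitric oxide synthase, inducible (Homo sapiens), with a stated time of 30 min, tested at 1 mM; a lower number here means less inhibition, a higher number more inhibition at the concentration tested (going by the name of the read-out). All three values lie within the usual scatter of one another, so none can be singled out as weaker or stronger. Compound 2 and compound 3 differ in their cores by methyl in place of phenyl on a carbonyl carbon, and that change gives a number 1 percentage points higher from compound 2 to compound 3 (within the scatter). From compound 3 to compound 1 the change is chloro in place of hydrogen on an aromatic carbon, which gives a number 8.3 percentage points higher from compound 3 to compound 1 (within the scatter).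

Compound 4 `CC(=O)N1CCC(c2cc(Cl)ccc2N)=N1` has not yet been measured in this assay. It differs from compound 2 by chloro in place of hydrogen on an aromatic carbon. This is the same kind of change as that from compound 3 to compound 1, though the surroundings are described differently: in compound 4 the chloro sits meta to a group of 8 heavy atoms, whereas in compound 1 it sits meta to a large group. For compound 4 the expected step is a number 8.3 percentage points higher from compound 2 to compound 4 (within the scatter), which rests on the same kind of change having given a number 8.3 percentage points higher from compound 3 to compound 1 (within the scatter). Compound 4 is therefore estimated at 16%, expected to fall between 4% and 28%.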

Compound 4, a percentage reported as inhibition, at one concentration (the size of the read-out at that concentration, not a potency): 1.03%
Beside the measured number, compound 4's estimate is 15 percentage points above it; the whole stated range lies above it.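

In this assay, chloro in place of hydrogen on an aromatic carbon did not carry over from one core to the other, for a number 6.7 percentage points lower from compound 2 to compound 4 (within the scatter) sits apart from the earlier step on the core bearing the phenyl carbonyl: the same change on two cores in this assay, a number 8.3 percentage points higher (within the scatter) from compound 3 to compound 1 and a number 6.7 percentage points lower (within the scatter) from compound 2 to compound 4, 15 percentage points apart, beyond the scatter of two such steps. Seen from the other side, methyl in place of phenyl on a carbonyl carbon gives a number 16 percentage points lower from compound 1 to compound 4 (beyond the scatter), so that change also reads differently with chloro present than without it: the same change on two cores in this assay, a number 1 percentage points higher (within the scatter) from compound 2 to compound 3 and a number 16 percentage points higher (beyond the scatter) from compound 4 to compound 1, 15 percentage points apart, beyond the scatter of two such steps. For the compounds shown here, this shows only that the two changes do not add up across these four compounds; it does not show that chloro by itself moves the number on either core, as each chloro step lies within the scatter, and it gives no reason for the mismatch.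

The compounds shown leave open whether bromo or methoxy in place of the chloro would differ between the two cores in the same way, and whether a longer chain on the carbonyl carbon would follow methyl or phenyl. Potency also stays open: each of the four has a reading at one concentration only.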